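The source may hold more compounds than are shown below. What is called first, only, known or untested is meant among the compounds shown, and "the series" means these compounds.

Measured so far in a functional assay on MGC-803 cells (Homo sapiens) for inhibition, read by CCK-8 assay, with a stated time of 48 h; on this read-out lower numbers stand for stronger inhibition and higher numbers for weaker inhibition:
- Compound 1 `COc1ccc(CN(C(=O)CSC(=S)N2CCN(C(=O)OC(C)(C)C)CC2)c2cc(OC)c(OC)c(OC)c2)cc1`: 310 nM
- Compound 2 `COc1ccc(CN(C(=O)CSC(=S)N2CCN(C(=O)OC(C)(C)C)CC2)c2ccc(Cl)cc2)cc1`: > 20000 nM (a limit)
- Compound 3 `COc1ccc(CN(C(=O)CSC(=S)N2CCN(C(=O)OC(C)(C)C)CC2)c2ccccc2)cc1`: > 20000 nM (a limit)

Compound 3 has no numerical value, and its > 20000 nM is a limit of the assay. The series record shows (the limit of > 20000 nM in this assay, at which 2 of the 3 values shown sit).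

Compound 4 `COc1ccc(CN(C(=O)CSC(=S)N2CCN(C(=O)OC(C)(C)C)CC2)c2ccc(C)cc2)cc1` differs from compound 3 by methyl in place of hydrogen on an aromatic carbon, or phenyl to 4-methylphenyl.

The closest measured change is a step that the two limits leave unreadable from compound 2 to compound 3, where hydrogen replaces chloro, so it gives no size for a substituent at this place. The large steps are an at least 64-fold higher number from compound 1 to compound 2 (1.80 log units; beyond the scatter) and an at least 64-fold higher number from compound 1 to compound 3 (1.80 log units; beyond the scatter). Both remove the 3,4,5-trimethoxyphenyl group, and compound 4 lacks that group too. Among these three compounds, only compound 1 carries that group and only compound 1 gives a number in this assay. Methyl has not been measured here, so this comparison is the only guide. No step beyond the scatter is expected, and the estimated change is a number no higher from compound 3 to compound 4 (the limit leaves the size open). A report at the limit is the likeliest outcome. For compound 4 the estimated value is 20000 nM, with an expected range of 7000 nM to 40000 nM.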

Compound 4, half-maximal inhibitory concentration: > 20000 nM
Compound 4 gave a limit, no number; the forecaster's own chance of this, stated with the estimate: 80%; the middle value sits exactly at the limit.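

In this assay compound 4 gives > 20000 nM, which is a limit of the assay and not a number. With methyl, this position has now been tried with a carbon substituent as well as with chloro and hydrogen, and the replacement of the 3,4,5-trimethoxyphenyl group by 4-methylphenyl gives an at least 64-fold higher number from compound 1 to compound 4 (1.80 log units; beyond the scatter), the third large step of this kind. The steps that link compound 4 to compound 2 and compound 3 cannot be read, as both ends of each are limits, so no ranking of methyl, chloro and hydrogen follows, and the series stands as follows: the limit of > 20000 nM in this assay, at which 3 of the 4 values shown sit.

Still open, going by these compounds, is how much of the 3,4,5-trimethoxyphenyl group the number of compound 1 depends on, as a 4-methoxyphenyl or 3,4-dimethoxyphenyl group would sit between compound 1 and the compounds at the limit. Also open, on these data alone, is whether any other group on this ring, such as a hydroxyl, an amine or a longer alkoxy chain, gives a number in this assay at all.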